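Methoxy addition on the benzamide ring across two cores

A few compounds are considered here, and "the series" means these few. Any claim that something is new, unique, unknown or untested is made for them only; others in the source may bear on it.

Compound 1 `COc1ccc(C(=O)Nc2ccc(N(C)S(C)(=O)=O)c(OCc3cc(Cl)ccc3Cl)c2)cc1` and compound 2 `COc1ccc(C(=O)Nc2ccc(N(C)S(C)(=O)=O)c(OCc3cc(Cl)ccc3Cl)c2)cc1OC` share one core and differ in a single place: methoxy in place of hydrogen on an aromatic carbon. In a functional assay on SK-BR-3 cells (Homo sapiens) for antiproliferative activity, read by MTT assay, with a stated time of 48 h (a lower number here means a stronger inhibitor, a higher number a weaker inhibitor), compound 1 gives 490 nM, and compound 2 gives 3730 nM; the step of a 7.6-fold higher number from compound 1 to compound 2 (0.88 log units; beyond the scatter) goes toward weaker inhibition.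

Compound 3 `COc1ccc(C(=O)Nc2ccc(N(C)S(=O)(=O)C(F)(F)F)c(OCc3cc(OC)ccc3OC)c2)cc1` rests on a second core; how it differs from compound 1 is not broken down here. In this assay compound 3 gives 110 nM, the lowest of the three measured numbers, with compound 1 nearest and compound 2 furthest.

Compound 4 `COc1ccc(OC)c(COc2cc(NC(=O)c3ccc(OC)c(OC)c3)ccc2N(C)S(=O)(=O)C(F)(F)F)c1` stands to compound 3 as compound 2 stands to compound 1: methoxy in place of hydrogen on an aromatic carbon. The place is described in the same words for both pairs, so this is the same kind of change made on a different core. Within the data shown here, only one measured instance of it exists, so its size on the second core is unknown, and nothing among the measured compounds argues for a different direction.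

For compound 4 the step is expected to resemble the earlier one, a 6.8-fold higher number from compound 3 to compound 4 (0.83 log units; beyond the scatter), because the pair compound 1 to compound 2 shows a 7.6-fold higher number from compound 1 to compound 2 (0.88 log units; beyond the scatter) for the same change. Compound 4 is therefore estimated at 750 nM, with a range from 250 nM to 2500 nM to allow for the change of core.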

Compound 4, half-maximal inhibitory concentration: 550 nM
For compound 4 the middle estimate is 1.4-fold (0.13 log units) above the measured one; the range from low to high includes it.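

In this assay, going from 4-methoxyphenyl to 3,4-dimethoxyphenyl gives a 5.0-fold higher number from compound 3 to compound 4 (0.70 log units; beyond the scatter), so the change moves toward weaker inhibition on the second core, as it does on the first. The size of the step also carries over, as the two steps cannot be told apart: the same change on two cores in this assay, a 7.6-fold higher number (0.88 log units; beyond the scatter) from compound 1 to compound 2 and a 5.0-fold higher number (0.70 log units; beyond the scatter) from compound 3 to compound 4, 1.5-fold (0.18 log units) apart, within the scatter of two such steps This holds for one pair on each of two cores and does not show that the change would behave the same way on a third core; the two cores also differ in more than one place, so neither pair tells which part of a core, if any, could alter the step.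

The compounds shown have only hydrogen or methoxy at this place, so it remains open whether a hydroxy, an ethoxy or an amine there would shift the number in the same direction or by a similar amount. Also open, as far as these compounds go, is whether the step keeps its size on a core that joins the trifluoromethyl sulfonyl part of compound 3 to the chlorine-bearing benzyl ether part of compound 1.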